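A few compounds are considered here, and "the series" means these few. Any claim that something is new, unique, unknown or untested is made for them only; others in the source may bear on it.

Three compounds of the series have so far been run in a functional assay on the whole organism (Tail, strain ICR) with Mus musculus as the target, in the tail flick test, with a stated time of 120 min, at a dose of 25 umol/kg by the oral route; on this read-out lower numbers stand for a weaker effect and higher numbers for a stronger effect at the one dose given. Compound 1 `CSCC[C@H](NC(=O)CN(c1nc(Cl)nc2[nH]cnc12)C1CC1)C(=O)OCc1ccccc1` gives 31.6%, compound 2 `CC(C)C[C@H](NC(=O)CN(c1nc(Cl)nc2[nH]cnc12)C1CC1)C(=O)OCc1ccccc1` gives 8.58%, and compound 3 `CC(C)C[C@H](NC(=O)CN(c1ncnc2c1ncn2C1CCCCO1)C1CC1)C(=O)OCc1ccccc1` gives 12.8%. Compound 1 and compound 2 share one core and differ in one place only: (methylsulfanyl)methyl in place of isopropyl on a saturated chain carbon, two bonds along the chain from an amide-type nitrogen and a carbonyl carbon. That change made a step of a number 23 percentage points higher from compound 2 to compound 1 (beyond the scatter). Compound 3 carries a different core; how its core differs from that of compound 2 is not broken down here, and the values of compound 2 and compound 3 lie within the scatter of each other.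

Compound 4 `CSCC[C@H](NC(=O)CN(c1ncnc2c1ncn2C1CCCCO1)C1CC1)C(=O)OCc1ccccc1` has not been measured. It stands to compound 3 as compound 1 stands to compound 2, the change being ((methylsulfanyl)methyl in place of isopropyl on a saturated chain carbon, two bonds along the chain from an amide-type nitrogen and a carbonyl carbon), the same change at the same place, now on the core of compound 3. In this assay a step of similar size is expected because a number 23 percentage points higher from compound 2 to compound 1 (beyond the scatter) was beyond the scatter, though this rests on a single pair and the other core may not carry it equally; the expected step is a number 21.2 percentage points higher from compound 3 to compound 4 (beyond the scatter). On that basis compound 4 is estimated at 34%, with a likely range of 16% to 52%.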

Compound 4, a percentage reported as activity, at one dose (the size of the read-out at that dose, not a potency): 28.7%
Estimate against measurement, compound 4: 5.3 percentage points above; low and high end bracket the measured number.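

In this assay, (methylsulfanyl)methyl in place of isopropyl, on a saturated chain carbon, two bonds along the chain from an amide-type nitrogen and a carbonyl carbon, also gives a rise on the second core, with a number 15.9 percentage points higher from compound 3 to compound 4 (beyond the scatter) in this pair. Set beside the earlier step, the change carries over in the same direction, and the two cores cannot be told apart by the size of the step: the same change on two cores in this assay, a number 23 percentage points higher (beyond the scatter) from compound 2 to compound 1 and a number 15.9 percentage points higher (beyond the scatter) from compound 3 to compound 4, 7.1 percentage points apart, within the scatter of two such steps. This does not show that the step holds on any further core, since it rests on one pair for each of two cores, read at a single dose and a single time.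

On these data alone, it remains open how other groups at the same place would read, for example a 2-(methoxy)ethyl chain, a longer chain or an amine. Also open, as far as these compounds go, is whether the step survives when a carboxylic acid stands in place of the benzyl ester.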